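Dropping the bromine from a coumarin-type amide

The source may hold more compounds than are shown below. What is called first, only, known or untested is meant among the compounds shown, and "the series" means these compounds.

Of the compounds shown here, three have been tested in a functional assay on HepG2 cells (Homo sapiens) for antiproliferative activity, read by fluorescence and resazurin assay, with a stated time of 48 h; a higher number here means a weaker inhibitor, a lower number a stronger inhibitor. Compound 1, `O=C(N/N=C/c1cccnc1)c1cc2cc(Br)ccc2oc1=O`, gives 19000 nM. Compound 2, `CCOc1ccc(NC(=O)c2cc3cc(Br)ccc3oc2=O)cc1`, gives 37000 nM. Compound 3, `O=C(N/N=C/c1cc2ccccc2nc1Cl)c1cc2cc([N+](=O)[O-])ccc2oc1=O`, gives 22800 nM. Compound 2 has the highest of the three numbers, but the gaps to compound 3 and to compound 1 both lie within the usual scatter, so no order among the three can be claimed.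

Compound 4, `CCOc1ccc(NC(=O)c2cc3ccccc3oc2=O)cc1`, has not yet been measured. It differs from compound 2 in one place: hydrogen in place of bromo on an aromatic carbon. The bromo group sits on an aromatic carbon of a six-membered aromatic ring of carbon only, part of a fused or bridged system of two rings, meta to a fused ring and para to a fused ring.

Among the measured compounds shown here, no pair of measured compounds shows this change, so nothing here tells how much a bromine contributes. Compound 2 is already a weak inhibitor, and the loss of one heavy atom is expected to move the number only a little, if at all. The step of a 1.4-fold higher number from compound 2 to compound 4 (0.13 log units; within the scatter) is expected to be small, perhaps a slight weakening, and possibly none beyond the scatter. Compound 4 is therefore expected to give about 50000 nM in this assay, with a range from 15000 nM to 160000 nM.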

Compound 4, half-maximal inhibitory concentration: 10400 nM
Compound 4: the middle estimate sits 4.8-fold (0.68 log units) above what was measured; the whole stated range lies above it.
By their numbers in this assay, from the lowest: compounds 4, 1, 3 and 2 (each within the scatter of the next, the first and the last beyond it).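

In this assay, replacing the bromo group with hydrogen gives a 3.6-fold lower number from compound 2 to compound 4 (0.55 log units; beyond the scatter), so in this amide the compound without bromine is the stronger inhibitor, and the step lies beyond the scatter. Among the compounds shown here, this is the first pair of compounds that differ in one place only, and it shows that what sits on this aromatic carbon can measurably change the number, even though the change removes a single heavy atom. Nothing available here accounts for the size or direction of this step.

Going by these compounds, compound 1 also carries a bromo group but has a different chain on the shared core, so it remains open whether hydrogen would lower its number too. Also open, on these data alone, is how a fluoro, methyl or amino group on this same aromatic carbon would compare with hydrogen and bromo.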